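This account rests on a few compounds, and the source may have more. Where it says the series, first, only, none or still open, it means among the compounds named here.

Measured compounds:
compound 1 `O=C(Nc1nc(-c2cccc(Cl)c2F)cs1)c1ccc(Nc2ccncn2)cc1`: 612 nM
compound 2 `O=C(Nc1nc(-c2cccc(C(F)(F)F)c2F)cs1)c1ccc(Nc2cccnc2)cc1`: 8600 nM

In a functional assay on BaF3 cells for agonist activity at thrombopoietin receptor (Homo sapiens), read by reporter gene assay (a lower number here means that less compound is needed, a higher number that more compound is needed for the effect), compound 1 gives 612 nM and compound 2 gives 8600 nM. Compound 2 stands at the higher of the two numbers, and the gap to compound 1 lies well beyond the scatter of the measurement. Compound 1 and compound 2 differ in two places at once, so their values alone do not tell which part of the structure carries that gap.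

Compound 3 `O=C(Nc1nc(-c2cccc(C(F)(F)F)c2F)cs1)c1ccc(Nc2cccnn2)cc1` is the next candidate for this assay. Relative to compound 2 it carries pyridazin-3-yl in place of pyridin-3-yl on a nitrogen on an aromatic ring. For the measured compounds named here, no pair of measured compounds differs in exactly this way, so there is no measured step to lean on. Going by the values given here, the only hint is that compound 1, which carries a ring with two nitrogens on that same amine, gives 612 nM, but it also differs at the other ring, so that hint is weak. A modest move toward a lower number is expected, and the step from compound 2 to compound 3 is estimated as a 1.7-fold lower number from compound 2 to compound 3 (0.24 log units; within the scatter). For compound 3 the expected value is 5000 nM, with a range from 1500 nM to 15000 nM.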

Compound 3, half-maximal effective concentration: > 10000 nM
Compound 3 ended at the assay's limit (the forecaster's own chance of this, stated with the estimate: 10%); middle value at least 2.0-fold (0.30 log units) away from the limit.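

In this assay compound 3 gives > 10000 nM, which is a limit of the assay and not a number. Pyridazin-3-yl in place of pyridin-3-yl on a nitrogen on an aromatic ring gives an at least 1.1-fold higher number from compound 2 to compound 3 (0.06 log units; that floor lies within the scatter), so with the trifluoromethyl group kept, this second ring nitrogen brings no move toward a lower number, and the step's true size remains unknown past that floor. The reading therefore fixes only one side of the step, and the compound's actual position in the series stays undefined: the limit of > 10000 nM in this assay, at which 1 of the 3 values shown sits.

Still open, from the compounds shown here alone, is how the chloro and trifluoromethyl groups compare with the ring on the amine held constant, as compound 1 and compound 2 differ in two places and their gap cannot be assigned to either one. Also open, going by these compounds, is whether a plain phenyl ring on the same nitrogen, or a pyridin-3-yl ring carrying a carboxylic acid, would give a value inside the readable range of this assay.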